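The compounds below may be only part of what the source reports. "The series", "measured", "known", "first", "only" and "open" are said of these compounds alone.

Measured so far in a physicochemical assay for solubility, measured as kinetic solubility, with a stated time of 24 h, at pH 7.4; a lower number here means a less soluble compound, a higher number a more soluble compound:
- compound 1 `O=C(NCc1ccc(S(=O)(=O)c2cc(F)cc(F)c2)cc1)c1cc2ccncc2o1` gives 5900 nM
- compound 2 `O=C(NCc1ccc(S(=O)(=O)c2cc(F)cc(F)c2)cc1)c1cc2cnccc2[nH]1` gives 1600 nM

For the measured compounds named here, compound 1 holds the higher of the two numbers, and the only measured step is a 3.7-fold lower number from compound 1 to compound 2 (0.57 log units; beyond the scatter). Compound 3 `O=C(NCc1ccc(S(=O)(=O)N2CCOCC2)cc1)c1cc2ccncc2o1` is not yet measured. Its difference from compound 1 is morpholin-4-yl in place of 3,5-difluorophenyl on a sulfonyl sulfur, with morpholin-4-yl in place of 3,5-difluorophenyl on a sulfonyl sulfur. The measured step lies at another place, on a carbonyl carbon, so it bears only loosely on this change: it gives a scale for one single change in the series and no direction for this one. Going by the values given here, no measured compound carries morpholin-4-yl. A larger move towards a higher number is therefore expected, as a judgement from the structural change alone. The expected step is a 6.8-fold higher number from compound 1 to compound 3 (0.83 log units; beyond the scatter). Compound 3 is estimated at 40000 nM, with an expected range of 12000 nM to 150000 nM.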

Compound 3, solubility: 101000 nM
Estimate against measurement, compound 3: 2.5-fold (0.40 log units) below; low and high end bracket the measured number.
By their numbers in this assay, from the lowest: compound 2; then compound 1; then compound 3.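

In this assay, the sulfonyl sulfur is now shown to be a place where a single change can move the number substantially: a 17-fold higher number from compound 1 to compound 3 (1.23 log units; beyond the scatter) with morpholin-4-yl in place of 3,5-difluorophenyl. This step is larger than the only earlier one, on a carbonyl carbon (a 3.7-fold lower number from compound 1 to compound 2 (0.57 log units; beyond the scatter)), and it runs the opposite way. No supporting measurement bears on the origin of this step, and the change replaces an all-carbon aromatic ring and both fluorines with a non-aromatic ring holding nitrogen and oxygen, all at once.

Still open, on these data alone, is whether the ring oxygen of morpholin-4-yl matters, which piperidin-1-yl or an open-chain dimethylamino group on the sulfonyl sulfur would help to separate. Also open, as far as these compounds go, is whether the step carries over to the core of compound 2.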